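Adding methyl to the amino group of compound 2

The compounds below may be only part of what the source reports. "The series", "measured", "known", "first", "only" and "open" are said of these compounds alone.

Measured in a functional assay on OCI-AML2 cells (Homo sapiens) for antiproliferative activity, read by WST assay, with a stated time of 3 days; a higher number here means a weaker inhibitor, a lower number a stronger inhibitor:
compound 1 `O=c1cc(I)n([C@@H]2O[C@H](CO)[C@@H](O)[C@H]2O)c(=O)[nH]1`: > 50000 nM (a limit)
compound 2 `Nc1cc(=O)[nH]c(=O)n1[C@@H]1O[C@H](CO)[C@@H](O)[C@H]1O`: > 50000 nM (a limit)

Compound 2 has no numerical reading in this assay and is reported only as the limit > 50000 nM. Within the data shown here, the series so far gives only (the limit of > 50000 nM in this assay, at which 2 of the 2 values shown sit).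

Compound 3 `CNc1cc(=O)[nH]c(=O)n1[C@@H]1O[C@H](CO)[C@@H](O)[C@H]1O` has methyl in place of hydrogen on a nitrogen on an aromatic ring, that is, amino to methylamino (methyl in place of hydrogen on a nitrogen on an aromatic ring).

Among the measured compounds shown here, one measured step bears on this change, and it replaces iodo with amino: a step that the two limits leave unreadable from compound 1 to compound 2. It offers no size to carry over, so no step beyond the scatter is expected in this assay. The expected step, an estimate only, is an at least 1.2-fold lower number from compound 2 to compound 3 (0.09 log units; that floor lies within the scatter). The estimated value for compound 3 is 40000 nM, within an expected range of 10000 nM to 100000 nM.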

Compound 3, half-maximal inhibitory concentration: > 50000 nM
Compound 3 ended at the assay's limit; the forecaster's own chance of this, stated with the estimate: 80%; middle value at least 1.2-fold (0.09 log units) from the limit.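

No step can be read among compound 1, compound 2 and compound 3, because all three values are limits rather than numbers: the limit of > 50000 nM in this assay, at which 3 of the 3 values shown sit.

The compounds shown leave open whether amino to methylamino, or either group in place of iodo, changes the antiproliferative activity at all.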